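Amide-nitrogen variation: compounds 1 to 3

The compounds below may be only part of what the source reports. "The series", "measured", "known", "first", "only" and "open" are said of these compounds alone.

Measured so far:
compound 1, `COc1ccc2c(=O)c(/C=C/C(=O)NCc3ccc(F)cc3)coc2c1`, 133000 nM
compound 2, `COc1ccc2c(=O)c(/C=C/C(=O)Nc3ccccc3C)coc2c1`, 59700 nM

Both values come from an ADME assay on HepG2 2.2.15 cells (Homo sapiens) for cytotoxicity, read by MTT assay, with stated times of 48 h and 9 days; on this read-out lower numbers stand for higher toxicity in this test and higher numbers for lower toxicity in this test. On these two numbers compound 2 stands lowest: a 2.2-fold lower number from compound 1 to compound 2 (0.35 log units; beyond the scatter). Compound 3, `COc1ccc2c(=O)c(/C=C/C(=O)Nc3ccc(Cl)cc3)coc2c1`, is not yet measured in this assay; it differs from compound 2 by 4-chlorophenyl in place of 2-methylphenyl on an amide-type nitrogen. For the measured compounds named here, the only measured step bears on it indirectly, since it exchanged a benzyl for a phenyl rather than one phenyl substituent for another. No step beyond the scatter is therefore expected in this assay. Compound 3 is estimated at 50000 nM, range 20000 nM to 140000 nM. The expected step is a 1.2-fold lower number from compound 2 to compound 3 (0.08 log units; within the scatter).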

Compound 3, half-maximal cytotoxic concentration: 272000 nM
Compound 3: the middle estimate sits 5.4-fold (0.74 log units) below what was measured; measured number above the stated range.
By their numbers in this assay, from the lowest: compound 2; then compound 1; then compound 3.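

In this assay, the substituted phenyl on the amide-type nitrogen makes a difference of its own: a 4.6-fold higher number from compound 2 to compound 3 (0.66 log units; beyond the scatter) with 4-chlorophenyl in place of 2-methylphenyl. A phenyl on this nitrogen therefore does not by itself give the lower number, as a 2.0-fold higher number from compound 1 to compound 3 (0.31 log units; beyond the scatter) with 4-chlorophenyl in place of 4-fluorobenzyl, while 2-methylphenyl stood on the other side of 4-fluorobenzyl. No measurement at hand explains this order.

Still open, going by these compounds, is whether the chlorine or the methyl drives the step, since the two groups differ in both substituent and its place on the ring. A 4-methylphenyl or 2-chlorophenyl on the same nitrogen would separate these.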